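Tetrazole nitrogen substituent: methyl exchanged for phenyl

The compounds below may be only part of what the source reports. "The series", "measured", "known", "first", "only" and "open" are said of these compounds alone.

Measured so far:
- Compound 1 `Cc1nc(C)c(CSc2nc(C)c(CC(=O)O)s2)nc1C`: in a functional assay on ECV-304 cells (Homo sapiens), read by MTT assay, with stated times of 24 h and 12 h, tested at 25 uM (a lower number here means a weaker effect, a higher number a stronger effect of the compound at the concentration tested), compound 1 gives 46.2%.
- Compound 2 `Cc1nc(C)c(CSc2nnnn2C)nc1C`: in this assay compound 2 gives -180%.

Compound 2 stands lowest of the two numbers in this assay; its nearest neighbour is compound 1, whose value lies higher by a gap beyond the scatter. Among the measured compounds shown here, no two measured compounds differ in a single place, so no measured step is available as a guide. Compound 3 `Cc1nc(C)c(CSc2nnnn2-c2ccccc2)nc1C` differs from compound 2 in one place: phenyl in place of methyl on an aromatic nitrogen. For the measured compounds named here, nothing among the measured compounds shows what this exchange does in this assay. A step beyond the scatter is nonetheless expected, with the more likely direction toward the less negative side, because compound 1 gives 46.2% in this assay. The expected step is a number 110 percentage points higher from compound 2 to compound 3 (beyond the scatter). For compound 3 the estimate is -70%, with a range from -200% to 50%.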

Compound 3, a percentage reported as activity, at one concentration (the size of the read-out at that concentration, not a potency): -119%
Estimate against measurement, compound 3: 49 percentage points above; low and high end bracket the measured number.
By their numbers in this assay, from the lowest: compound 2; then compound 3; then compound 1.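

In this assay, the aromatic nitrogen of the five-membered ring with 4 nitrogen now has its first measured exchange: phenyl in place of methyl gives a number 61 percentage points higher from compound 2 to compound 3 (beyond the scatter). The read-out therefore responds to the group at this position, yet the exchange does not lift it out of the negative range, as compound 3 still gives -119%. Nothing measured here accounts for the step.

On these data alone, it remains open whether the step follows the aromatic ring itself or simply the larger group, which a cyclohexyl or a benzyl group on the same nitrogen would help to separate. Also open, as far as these compounds go, is how a carboxylic acid or an amine carried on the phenyl ring would read in this assay.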